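A few compounds are considered here, and "the series" means these few. Any claim that something is new, unique, unknown or untested is made for them only; others in the source may bear on it.

Of the compounds shown here, three have been measured in an ADME assay on H1-HeLa cells (Homo sapiens) for cytotoxicity, read by MTT assay, with a stated time of 3 days; on this read-out higher numbers stand for lower toxicity in this test and lower numbers for higher toxicity in this test. Compound 1 `CNC(=O)c1cc(Oc2ccc3cc(C(=O)OC)sc3c2)ccn1` carries a methoxycarbonyl group on its fused core, and in this assay compound 1 gives > 100000 nM, which is a limit of the assay rather than a number. Compound 2 `CNC(=O)c1cc(Oc2ccc3c(C)c(C(=O)OC)sc3c2)ccn1` differs from compound 1 by methyl in place of hydrogen on an aromatic carbon. In this assay compound 2 gives 10800 nM. The step of an at least 9.2-fold lower number from compound 1 to compound 2 (0.96 log units; beyond the scatter) means the methyl-bearing compound is the more toxic of the two, and because compound 1 sits at the limit of > 100000 nM in this assay, at which 2 of the 3 values shown sit, the size of this step is known only as a minimum.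

Compound 3 `CCOC(=O)c1cc2ccc(Oc3ccccc3)cc2s1` has a different core, bearing an ethoxycarbonyl group and a plain phenoxy group; how the two cores differ is not broken down here. In this assay compound 3 gives > 100000 nM, again a limit of the assay. Compound 4 `CCOC(=O)c1sc2cc(Oc3ccccc3)ccc2c1C` differs from compound 3 by methyl in place of hydrogen on an aromatic carbon. This is the same kind of change as that from compound 1 to compound 2, the places differing in that one is next to the ring atom that bears an ethoxycarbonyl group and the other next to the ring atom that bears a methoxycarbonyl group.

Resting on the step of an at least 9.2-fold lower number from compound 1 to compound 2 (0.96 log units; beyond the scatter), a step of an at least 5.0-fold lower number from compound 3 to compound 4 (0.69 log units; beyond the scatter) is expected. Compound 4 is expected to give about 20000 nM in this assay, with a range from 5000 nM to 100000 nM.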

Compound 4, half-maximal cytotoxic concentration: > 100000 nM
Compound 4 gave a limit, no number; the forecaster's own chance of this, stated with the estimate: 35%; middle value at least 5.0-fold (0.69 log units) from the limit.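

No step can be read from compound 3 to compound 4, because both compounds stand at a limit of the assay rather than at a number: the limit of > 100000 nM in this assay, at which 3 of the 4 values shown sit.

The compounds shown leave open whether methyl in place of hydrogen on an aromatic carbon changes toxicity at all in this assay on the core of compound 3, as it does from compound 1 to compound 2.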